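Cyclohexylsulfanyl in place of cyclopentyloxy: an expected step

The compounds below may be only part of what the source reports. "The series", "measured", "known", "first", "only" and "open" are said of these compounds alone.

Of the compounds shown here, three have numbers so far in an ADME assay on MT4 cells (Homo sapiens) for cytotoxicity, read by MTT assay (on this read-out higher numbers stand for lower toxicity in this test and lower numbers for higher toxicity in this test), and none of them has been tested twice here. Compound 2 (`Cc1cc(OC2CCCC2)nc(Nc2ccc(C#N)cc2)n1`) stands lowest of the three at 1050 nM on this read-out. Compound 3 (`N#Cc1ccc(Nc2nccc(NC3CCCCC3)n2)cc1`) is nearest at 7330 nM in the same test, and compound 1 (`Cc1cnc(Nc2ccc(C#N)cc2)nc1OC1CCCCC1`) is furthest at 31200 nM in the same test, both beyond the scatter from compound 2.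

Compound 4 (`Cc1cc(SC2CCCCC2)nc(Nc2ccc(C#N)cc2)n1`) carries cyclohexylsulfanyl in place of cyclopentyloxy on an aromatic carbon and still awaits a number in this assay for this series. Among the compounds with values here, no two measured compounds differ in one place only, so this step has no direct precedent, and no measured compound carries cyclohexylsulfanyl. Within the data shown here, the only guide is that compound 1 and compound 3, the two measured compounds with a six-membered non-aromatic ring of carbon only, both sit higher than compound 2, though each also differs from it elsewhere. A rise beyond the scatter is therefore expected, of uncertain size, and the expected step runs a 4.8-fold higher number from compound 2 to compound 4 (0.68 log units; beyond the scatter) on this reasoning. For compound 4 the estimate is 5000 nM with an expected range from 1300 nM to 22000 nM in this test.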

Compound 4, half-maximal cytotoxic concentration: >= 192000 nM
Compound 4 was reported as a limit; the forecaster's own chance of this, stated with the estimate: 10%; middle value at least 38-fold (1.58 log units) from the limit.
By their numbers in this assay, from the lowest: compound 2; then compound 3; then compound 1. At a limit, above all of these: compound 4.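

Within the data shown here, this is the first comparison that changes one place only, and it shows that the group on this aromatic carbon, with the rest of compound 2 unchanged, can by itself move the read-out in this assay by a large margin: an at least 180-fold higher number from compound 2 to compound 4 (2.26 log units; beyond the scatter), towards lower toxicity in this test. Cyclopentyloxy and cyclohexylsulfanyl have the same printed count of hydrogen-bond donors and acceptors and neither carries a net charge, so a large step at this position occurs with those counts unchanged. The result for compound 4 is a limit and not a number: the limit of >= 192000 nM in this assay, at which 1 of the 4 values shown sits.

The step changes the ring from five-membered to six-membered and the linking atom from oxygen to sulfur in one move, so the compounds shown cannot assign it to either change, and the full size of the step also remains unknown. A cyclopentylsulfanyl group on this carbon of the core of compound 2 would separate the two changes, since it would keep the five-membered ring of compound 2 and the sulfur of compound 4.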